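This account rests on a few compounds, and the source may have more. Where it says the series, first, only, none or still open, it means among the compounds named here.

Measured compounds in an ADME assay on HCT-116 cells (Homo sapiens) for cytotoxicity, read by CellTiter-Glo, with a stated time of 72 h; on this read-out higher numbers stand for weaker inhibition and lower numbers for stronger inhibition:
Compound 1 `CC1CCN(C2CCN(S(=O)(=O)c3cccnc3Cl)CC2)CC1` gives > 10000 nM, which is a limit of the assay rather than a number.
Compound 2 `Cc1cc(C)c(S(=O)(=O)N2CCC(N3CCC(Cc4ccc(F)cc4)CC3)CC2)c(C)c1` gives > 5000 nM, also a limit of the assay.

Compound 1 therefore stands nowhere on a scale of numbers: its result is only a limit, the one at which one of the two shown values sits (the limit of > 10000 nM in this assay, at which 1 of the 2 values shown sits). The other shown value sits at a different limit (the limit of > 5000 nM in this assay, at which 1 of the 2 values shown sits), so neither measured compound offers a number, and no step between measured compounds that differ in one place exists to guide an expectation.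

Compound 3 `CC1CCN(C2CCN(S(=O)(=O)c3cc(Cl)cc(Cl)c3)CC2)CC1` differs from compound 1 by 3,5-dichlorophenyl in place of 2-chloropyridin-3-yl on a sulfonyl sulfur. With compound 1 already at a limit and both measured results weak, no step beyond the usual scatter is expected in this assay; a limit is the likeliest outcome again. Compound 3 is expected to give about 15000 nM, within 5000 nM to 50000 nM. The expected step that the limit leaves unreadable from compound 1 to compound 3 is essentially none.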

Compound 3, half-maximal inhibitory concentration: > 5000 nM
Compound 3: no number, only a limit; the forecaster's own chance of this, stated with the estimate: 80%; the middle value is on the limit's open side.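

Compound 1 and compound 3 both give only limits in this assay, and the step between them cannot be read. The compounds shown leave open whether any of them, with either group on the sulfonyl sulfur, would give an actual number in this assay.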